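Terminal Cyano Removed From an Allyl Acetophenone Ether

This account rests on a few compounds, and the source may have more. Where it says the series, first, only, none or still open, it means among the compounds named here.

Of the compounds shown here, three built on one shared core have been tested in an assay on isolated protein for inhibition of leukotriene B4 receptor 1 (Homo sapiens), tested at 10 uM; a higher number here means more inhibition at the concentration tested (going by the name of the read-out), a lower number less inhibition. Compound 1, `C=CCc1cc(C(C)=O)c(O)cc1OCCCCCC#N`, gives 81%, the lowest of the three numbers. Compound 2, `CCc1cc(C(C)=O)c(O)cc1OCCCC(C)(C)C#N`, gives 85%, a number within the usual scatter of that of compound 1, so no order between those two can be read. Compound 3, `CCc1cc(C(C)=O)c(O)cc1OCCCCCC(C)(C)c1nnnn1C`, gives 99%, which stands beyond the scatter above compound 1.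

The step of interest leads from compound 1 to compound 4, `C=CCc1cc(C(C)=O)c(O)cc1OCCCCC`, which has not yet been measured in this assay. The change is hydrogen in place of cyano on a saturated chain carbon, five bonds along the chain from an oxygen on an aromatic ring. Every measured compound carries a group at the far end of the chain from the aromatic oxygen, whereas compound 4 ends in hydrogen there, a situation for which the three measured compounds offer no direct parallel.

For the measured compounds named here, since no single-point step between measured compounds is available, the expectation rests on the whole set. A loss of inhibition beyond the scatter is expected for compound 4, and the expected step of a number 31 percentage points lower from compound 1 to compound 4 (beyond the scatter) reflects that. Compound 4 is estimated at 50%, within a range from 20% to 78%.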

Compound 4, a percentage reported as inhibition, at one concentration (the size of the read-out at that concentration, not a potency): 60%
For compound 4 the middle estimate is 10 percentage points below the measured one, and the stated range covers the measured number.
By their numbers in this assay, from the lowest: compound 4; then compounds 1 and 2 (each within the scatter of the next); then compound 3.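

In this assay, for the compounds shown here, the change to hydrogen in place of cyano on a saturated chain carbon, five bonds along the chain from an oxygen on an aromatic ring, gives a number 21 percentage points lower from compound 1 to compound 4 (beyond the scatter), a modest step and the first comparison in this set that isolates this position. It shows that inhibition at the tested concentration depends on what stands at the end of this chain, yet the cyano is not needed for all of it, since compound 4 still gives 60%. Nothing available explains what lies behind this step.

The compounds shown leave open whether the nitrile itself matters or whether another end group, such as a carboxylic acid, a primary amide or an amine, would serve equally well at this position. They also leave open whether the same change would give a step of similar size on a core carrying ethyl in place of allyl, and, as each value is a percentage at a single concentration, how the change affects potency.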